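Half-life expected for the naphthalen-2-yl compound 4

This account rests on a few compounds, and the source may have more. Where it says the series, first, only, none or still open, it means among the compounds named here.

In an in vivo ADME assay on the whole organism (Cavia porcellus) (a lower number here means that the compound disappears faster, a higher number that the compound lasts longer), compound 1 (`CCCCC(NC(=O)c1ccc(C(=N)N)cc1)C(C)(C)C(=O)N1CCC(CC(=O)O)CC1`) gives 1.03 h as its half-life, compound 2 (`CCCCCC(NC(=O)c1ccc(C(=N)N)cc1)C(C)(C)C(=O)N1CCC(CC(=O)O)CC1`) gives 0.517 h as its half-life and compound 3 (`CC(C)(C(=O)N1CCC(CC(=O)O)CC1)C(CCc1ccccc1)NC(=O)c1ccc(C(=N)N)cc1`) gives 0.767 h as its half-life. Compound 3 cannot be told apart from either of the others: the record shows a 1.3-fold lower number from compound 1 to compound 3 (0.13 log units; within the scatter) and also a 1.5-fold higher number from compound 2 to compound 3 (0.17 log units; within the scatter) with a 2.0-fold lower number from compound 1 to compound 2 (0.30 log units; within the scatter) completing the set.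

Compound 4 (`CC(C)(C(=O)N1CCC(CC(=O)O)CC1)C(NC(=O)c1ccc(C(=N)N)cc1)c1ccc2ccccc2c1`) brings one structural change from compound 3: naphthalen-2-yl in place of phenethyl on a saturated chain carbon bound to an amide-type nitrogen and a saturated chain carbon so naphthalen-2-yl stands in place of phenethyl on a saturated chain carbon bound to an amide-type nitrogen and a saturated chain carbon. Within the data shown here, no measured step makes this exact swap. The nearest evidence is the two phenyl-for-chain steps, both within the scatter, so no step beyond the scatter is expected in this assay for this change. The expected change is a 1.1-fold lower number from compound 3 to compound 4 (0.04 log units; within the scatter) on this estimate. For compound 4 the estimated half-life is 0.7 h with an expected range from 0.35 h to 1.4 h in this measurement.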

Compound 4, half-life: 0.85 h
Beside the measured number, compound 4's estimate is 1.2-fold (0.08 log units) below it; low and high end bracket the measured number.
By their numbers in this assay, from the lowest: compounds 2, 3, 4 and 1 (each within the scatter of the next).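

In this assay, the saturated chain carbon bound to an amide-type nitrogen and a saturated chain carbon now carries naphthalen-2-yl, and the half-life stays within the scatter of all three earlier compounds, with a 1.1-fold higher number from compound 3 to compound 4 (0.04 log units; within the scatter), a 1.6-fold higher number from compound 2 to compound 4 (0.22 log units; within the scatter) and a 1.2-fold lower number from compound 1 to compound 4 (0.08 log units; within the scatter). Among these compounds, until now this place had held only butyl, pentyl and phenethyl, so this is the first sign that a group with 2 six-membered aromatic rings of carbon only is not separated from those groups by this read-out. Nothing available explains why the half-life stays within this range.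

The compounds shown leave open whether an amine, a carboxylic acid or a group as small as methyl at this place would move the half-life beyond the scatter. They also leave open whether naphthalen-1-yl would behave like naphthalen-2-yl.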